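Isopropoxy in place of methoxy on a urea series

The compounds below may be only part of what the source reports. "The series", "measured", "known", "first", "only" and "open" are said of these compounds alone.

Measured compounds:
- Compound 1, `CN1CCN(C(=O)Nc2cc(Cl)nc(Cl)c2)CC1`: 521000 nM
- Compound 2, `O=C(Nc1cc(Cl)nc(Cl)c1)Nc1cc(Cl)nc(Cl)c1`: 9440 nM
- Compound 3, `COc1cc(NC(=O)Nc2cc(Cl)nc(Cl)c2)cc(Cl)n1`: 33200 nM

In an ADME assay on NCM460 cells (Homo sapiens) for cytotoxicity, read by MTT assay, with a stated time of 72 h, in the presence of a further agent that is not named here (a lower number here means that less compound is needed, a higher number that more compound is needed for the effect), compound 3 gives 33200 nM, the second highest of the three numbers. Its nearest neighbour is compound 2, whose value of 9440 nM is lower; the furthest is compound 1, whose value of 521000 nM is far higher. Among the compounds with values here, the only single-point step measured here is a 3.5-fold higher number from compound 2 to compound 3 (0.55 log units; beyond the scatter), a methoxy in place of chloro on an aromatic carbon.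

Compound 4, `CC(C)Oc1cc(NC(=O)Nc2cc(Cl)nc(Cl)c2)cc(Cl)n1`, differs from compound 3 by isopropyl in place of methyl on an oxygen on an aromatic ring. Within the data shown here, no measured pair shows what happens when a methyl on such an oxygen grows to isopropyl, so the measured step from compound 2 to compound 3 does not bear directly on it; it only shows that a change at this position of the core can move this assay modestly. Among the measured compounds shown here, with no comparable step to draw on, the expected step of a 1.1-fold lower number from compound 3 to compound 4 (0.04 log units; within the scatter) is none beyond the usual scatter. Compound 4 is therefore estimated at 30000 nM, with a range from 9000 nM to 100000 nM.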

Compound 4, half-maximal effective concentration: 21100 nM
Beside the measured number, compound 4's estimate is 1.4-fold (0.15 log units) above it, and the stated range covers the measured number.
By their numbers in this assay, from the lowest: compound 2; then compounds 4 and 3 (each within the scatter of the next); then compound 1.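

In this assay, isopropyl in place of methyl on an oxygen on an aromatic ring gives a 1.6-fold lower number from compound 3 to compound 4 (0.20 log units; within the scatter) and stays within the usual scatter, so the number does not respond measurably to this larger group on the oxygen. Exchanging the chloro for isopropoxy gives a 2.2-fold higher number from compound 2 to compound 4 (0.35 log units; beyond the scatter) as a modest step beyond the scatter, and methoxy in the same place also gives a higher number with a 3.5-fold higher number from compound 2 to compound 3 (0.55 log units; beyond the scatter), so both groups sit on the same side of chloro. Nothing measured here accounts for these numbers.

One pair cannot show whether the insensitivity at this oxygen extends to a longer chain such as butyl, or to a ring such as cyclohexyl. Going by these compounds, an amine in place of the chloro or the isopropoxy also remains open.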